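The source may report more compounds than this note shows. Statements on the series, on what has been measured and on what is new or still open speak of the compounds shown alone.

Two compounds have been measured in a functional assay on cells for agonist activity at Free fatty acid receptor 1 (Homo sapiens), read by FLIPR and calcium flux; a lower number here means that less compound is needed, a higher number that more compound is needed for the effect:
compound 1, `CC#C[C@@H](Cc1nnn[nH]1)c1ccc(OCc2ccc3sc(F)c(-c4ccccc4C)c3c2)cc1`, giving 15 nM;
compound 2, `CC#C[C@@H](Cc1nnn[nH]1)c1ccc(OCc2ccc3sc(Cl)c(-c4ccccc4C)c3c2)cc1`, giving 20 nM.

Within the data shown here, compound 2 stands at the top of these two numbers, but its only neighbour is compound 1, and the step of a 1.3-fold higher number from compound 1 to compound 2 (0.12 log units; within the scatter) lies within the scatter of the method, so the two values cannot be told apart. Compound 3 is `CC#C[C@@H](Cc1nnn[nH]1)c1ccc(OCc2ccc3sc(C)c(-c4ccccc4C)c3c2)cc1`; its change from compound 2 is methyl in place of chloro on an aromatic carbon. Among the measured compounds shown here, the one measured step that bears on this aromatic carbon is a 1.3-fold higher number from compound 1 to compound 2 (0.12 log units; within the scatter), an exchange of one halogen for another that left the number essentially where it was. For the measured compounds named here, no measured step exchanges a halogen for a methyl there. On that basis only a small step is expected. For compound 3 the expected step is a 1.1-fold higher number from compound 2 to compound 3 (0.04 log units; within the scatter). Compound 3 is therefore estimated at 22 nM, within 8 nM to 60 nM.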

Compound 3, half-maximal effective concentration: 20 nM
The estimate for compound 3 lay 1.1-fold (0.04 log units) above the measured number; measured number inside the range.
By their numbers in this assay, from the lowest: compounds 1, 2 and 3 (each within the scatter of the next).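

In this assay, putting methyl in place of chloro on this aromatic carbon next to the ring sulfur gives no change at the digits printed from compound 2 to compound 3 (within the scatter), and putting methyl in place of fluoro gives a 1.3-fold higher number from compound 1 to compound 3 (0.12 log units; within the scatter). The earlier pair had shown only one halogen exchanged for another, whereas these steps show that a methyl can also stand at this position with a value that cannot be told apart from those of either halogen compound. Nothing available explains why the three groups read alike.

The compounds shown leave open how an amine, a carboxylic acid or a longer chain on this aromatic carbon would read. They also leave open whether the three groups would still read alike if the neighbouring ring atom bore something other than the 2-methylphenyl group.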